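Aryl swap on the thiourea nitrogen: outlook for compound 4

The source may report more compounds than this note shows. Statements on the series, on what has been measured and on what is new or still open speak of the compounds shown alone.

Compound 3 `NC(=O)c1c(NC(=O)c2ccccc2Cl)sc2c1CCN(C(=S)Nc1ccccc1-c1ccccc1)C2` gives 24000 nM in a functional assay on HeLa cells (Homo sapiens) for antiproliferative activity, with a stated time of 24 h (on this read-out lower numbers stand for stronger inhibition and higher numbers for weaker inhibition), the lowest of the three numbers to date, though compound 1 `NC(=O)c1c(NC(=O)c2ccccc2Cl)sc2c1CCN(Cc1c(Cl)cccc1Cl)C2` with 28800 nM and compound 2 `NC(=O)c1c(NC(=O)c2ccccc2Cl)sc2c1CCN(C(=S)Nc1ccccc1)C2` with 46700 nM both sit within the scatter of it, so no order among the three can be claimed. Among the measured compounds shown here, two measured steps bear on the next change: a 1.6-fold higher number from compound 1 to compound 2 (0.21 log units; within the scatter) and a 1.9-fold lower number from compound 2 to compound 3 (0.29 log units; within the scatter), neither of them beyond the scatter. Compound 4 `COc1ccc(NC(=S)N2CCc3c(sc(NC(=O)c4ccccc4Cl)c3C(N)=O)C2)cc1` differs from compound 3 by 4-methoxyphenyl in place of 2-phenylphenyl on an amide-type nitrogen. For the measured compounds named here, the phenyl whose entry gave a 1.9-fold lower number from compound 2 to compound 3 (0.29 log units; within the scatter) is thereby removed again, which on that step alone would point back toward the number of compound 2, while the incoming methoxy group has no measured counterpart. Taken together, no step beyond the scatter is expected in this assay. Compound 4 is therefore estimated at 35000 nM, within a range of 15000 nM to 80000 nM. This estimate corresponds to an expected step of a 1.5-fold higher number from compound 3 to compound 4 (0.16 log units; within the scatter).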

Compound 4, half-maximal inhibitory concentration: 36400 nM
Compound 4: middle estimate off by 1.0-fold (0.02 log units), on the low side; measured number inside the range.
By their numbers in this assay, from the lowest: compounds 3, 1, 4 and 2 (each within the scatter of the next).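

In this assay, the group on the amide-type nitrogen has now been varied three ways with no step beyond the scatter: 4-methoxyphenyl in place of 2-phenylphenyl gives a 1.5-fold higher number from compound 3 to compound 4 (0.18 log units; within the scatter), and the methoxy group on its own gives a 1.3-fold lower number from compound 2 to compound 4 (0.11 log units; within the scatter). The larger exchange on the amine nitrogen in the ring also stays within the scatter, at a 1.3-fold higher number from compound 1 to compound 4 (0.10 log units; within the scatter), so none of the four compounds can be ranked against another. No supporting measurement bears on this result.

On these data alone, it remains open whether an amine or a carboxylic acid on the aromatic ring would produce a step beyond the scatter. The same holds for a longer chain between the amide-type nitrogen and that ring.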